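The source may hold more compounds than are shown below. What is called first, only, known or untested is meant among the compounds shown, and "the series" means these compounds.

Measured so far in an assay on HeLa cells for displacement of a labelled ligand from adenosine receptor A3 (Homo sapiens), read by fluorescence polarization, with a stated time of 30 min; a higher number here means a weaker inhibitor, a lower number a stronger inhibitor:
compound 1 `COc1ccc(-c2cc(NC(=O)CCC(=O)N(C)CC(=O)NC3CCCCC3)nc(-c3ccc(OC)cc3)n2)cc1` — 18500 nM
compound 2 `COc1ccc(-c2cc(NC(=O)CCC(=O)N(C)CC(=O)NCc3ccccc3)nc(-c3ccc(OC)cc3)n2)cc1` — 9500 nM
compound 3 `COc1ccc(-c2cc(NC(=O)COCC(=O)NCC(=O)NC3CCCCC3)nc(-c3ccc(OC)cc3)n2)cc1` — 14000 nM

Compound 3 stands second highest of the three numbers; its gaps to compound 1 and to compound 2 are both within the scatter, so no order among the three can be read. Compound 4 `COc1ccc(-c2cc(NC(=O)COCC(=O)N(C)CC(=O)NC3CCCCC3)nc(-c3ccc(OC)cc3)n2)cc1` differs from compound 3 by methyl in place of hydrogen on an amide-type nitrogen. Going by the values given here, no measured step covers this change: the one step in hand, a 1.9-fold lower number from compound 1 to compound 2 (0.29 log units; within the scatter), concerns a different position and is itself within the scatter. Compound 1 carries the methyl on that nitrogen but also a different chain, so its value does not isolate the change. For compound 4 in this assay no step beyond the scatter is expected, no change at the digits printed from compound 3 to compound 4 (within the scatter); the estimate is 14000 nM, range 5000 nM to 40000 nM.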

Compound 4, inhibition constant: 10100 nM
For compound 4 the middle estimate is 1.4-fold (0.14 log units) above the measured one; the measured number falls inside the stated range.
By their numbers in this assay, from the lowest: compounds 2, 4, 3 and 1 (each within the scatter of the next).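

Methyl in place of hydrogen on the amide-type nitrogen, whose other neighbours are a carbonyl carbon and a saturated chain carbon, gives a 1.4-fold lower number from compound 3 to compound 4 (0.14 log units; within the scatter) in this assay. This pair reads the change on its own, which compound 1 could not do with its different chain, and the amide hydrogen gives way to methyl without a step beyond the scatter. No measurement at hand accounts for this result.

From the compounds shown here alone, whether ethyl or a longer chain ending in a carboxylic acid on this nitrogen would move the number beyond the scatter stays open. Also open, going by these compounds, is whether methyl on this nitrogen reads the same with benzyl in place of cyclohexyl.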